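The source may hold more compounds than are shown below. What is called first, only, known or untested is meant among the compounds shown, and "the series" means these compounds.

Of the compounds shown here, three built on one shared core have been tested in a functional assay (QGY7701 cells, Homo sapiens) for inhibition, read by MTT assay, with a stated time of 48 h; a higher number here means a weaker inhibitor, a lower number a stronger inhibitor. Compound 1 `COc1ccc2c(=O)c(/C=C/C(=O)Nc3ccccc3)coc2c1` gives 14000 nM. Compound 2 `COc1ccc2c(=O)c(/C=C/C(=O)Nc3cc(C)ccc3C)coc2c1` reaches only the limit of this assay, > 100000 nM. Compound 3 `COc1ccc(NC(=O)/C=C/c2coc3cc(OC)ccc3c2=O)cc1` also stops at the limit, recorded as > 100000 nM. Two measured steps can be read: an at least 7.1-fold higher number from compound 1 to compound 2 (0.85 log units; beyond the scatter) and an at least 7.1-fold higher number from compound 1 to compound 3 (0.85 log units; beyond the scatter). The remaining step, a step that the two limits leave unreadable from compound 2 to compound 3, cannot be sized because both of its values rest at the limit of > 100000 nM in this assay, at which 2 of the 3 values shown sit. Compound 4 `COc1ccc(CNC(=O)/C=C/c2coc3cc(OC)ccc3c2=O)cc1` differs from compound 3 by 4-methoxybenzyl in place of 4-methoxyphenyl on an amide-type nitrogen. Going by the values given here, no measured step covers this exchange, so the expectation rests on compound 3 alone, which stands at the limit > 100000 nM. Compound 4 is therefore expected to give roughly 60000 nM, within 10000 nM to 200000 nM, an estimated step of an at least 1.6-fold lower number from compound 3 to compound 4 (0.22 log units; that floor lies within the scatter).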

Compound 4, half-maximal inhibitory concentration: 15700 nM
Compound 4: middle estimate off by 3.8-fold (0.58 log units), on the high side; low and high end bracket the measured number.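

On the amide-type nitrogen, 4-methoxybenzyl gives a readable value where aryl groups with substituents did not, with an at least 6.3-fold lower number from compound 3 to compound 4 (0.80 log units; beyond the scatter) and an at least 6.3-fold lower number from compound 2 to compound 4 (0.80 log units; beyond the scatter). Compared with plain phenyl, it gives a 1.1-fold higher number from compound 1 to compound 4 (0.05 log units; within the scatter), so compound 4 and compound 1 cannot be told apart. The first two steps are only minimum sizes, because compound 2 and compound 3 rest at a limit: the limit of > 100000 nM in this assay, at which 2 of the 4 values shown sit.

Going by these compounds, whether the methoxy group matters once the benzyl is in place remains open. Plain benzyl and a longer chain such as 2-phenylethyl on the same nitrogen would address this.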